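Series notes: naphthalen-2-yl in place of phenyl

A few compounds are considered here, and "the series" means these few. Any claim that something is new, unique, unknown or untested is made for them only; others in the source may bear on it.

Measured so far in a functional assay on cells (Cancer cell lines, Homo sapiens) for cytotoxicity, read by sulforhodamine B assay, with a stated time of 48 h; on this read-out lower numbers stand for stronger inhibition of growth and higher numbers for weaker inhibition of growth:
- compound 1 `O=C1N=C(N2N=C(c3ccccc3)CC2c2ccccc2O)S/C1=C1/C(=O)Nc2ccccc21` gives 4730 nM
- compound 2 `COc1ccc(C2CC(c3ccccc3)=NN2C2=NC(=O)/C(=C3\C(=O)Nc4ccccc43)S2)cc1` gives 6040 nM
- compound 3 `COc1ccc(C2CC(c3ccccc3)=NN2C2=NC(=O)/C(=C3\C(=O)Nc4ccc(Br)cc43)S2)cc1` gives 510 nM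

Compound 2 stands at the highest of the three numbers shown. Within the data shown here, its nearest neighbour is compound 1, since the step of a 1.3-fold higher number from compound 1 to compound 2 (0.11 log units; within the scatter) leaves the two level; the furthest is compound 3, reached by the step of a 12-fold lower number from compound 2 to compound 3 (1.07 log units; beyond the scatter), the only change in this set that moves the read-out clearly.

The next compound, compound 4 `COc1ccc(C2CC(c3ccc4ccccc4c3)=NN2C2=NC(=O)/C(=C3\C(=O)Nc4ccccc43)S2)cc1`, differs from compound 2 in one place: naphthalen-2-yl in place of phenyl on a carbon with a double bond to nitrogen. Among the measured compounds shown here, no measured step tests this kind of change. The step of a 1.3-fold higher number from compound 1 to compound 2 (0.11 log units; within the scatter) swaps a group on a saturated ring carbon and stays within the scatter; the step of a 12-fold lower number from compound 2 to compound 3 (1.07 log units; beyond the scatter) adds bromo on an aromatic carbon of the other end of the molecule. Neither enlarges the aromatic group on the carbon with a double bond to nitrogen, so the expectation rests on the shared core only.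

The step of a 1.5-fold lower number from compound 2 to compound 4 (0.18 log units; within the scatter) is therefore expected to be small and of uncertain direction, most likely within the scatter. Compound 4 is estimated at 4000 nM, with a range from 1200 nM to 12000 nM.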

Compound 4, concentration for total growth inhibition: 4030 nM
Compound 4: middle estimate off by 1.0-fold (0.00 log units), on the low side; low and high end bracket the measured number.
By their numbers in this assay, from the lowest: compound 3; then compounds 4, 1 and 2 (each within the scatter of the next).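

In this assay, among these compounds, the carbon with a double bond to nitrogen of the five-membered non-aromatic ring is probed here for the first time, and the step of a 1.5-fold lower number from compound 2 to compound 4 (0.18 log units; within the scatter) is the only reading at this position. Replacing phenyl, with one six-membered aromatic ring of carbon only, by naphthalen-2-yl, with 2 such rings and 10 heavy atoms instead of 6, leaves the read-out level, so this position accepts a clearly larger aromatic group with no change beyond the scatter. Nothing at hand bears on why the read-out holds level across this change.

The compounds shown carry only phenyl and naphthalen-2-yl at this position, so it remains open whether a smaller or non-aromatic group there, such as a methyl group, a primary amine or a carboxylic acid, would move the read-out. Also open, going by these compounds, is whether naphthalen-2-yl at this position keeps the read-out level when bromo sits on the aromatic carbon that carries it in compound 3.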